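The source may report more compounds than this note shows. Statements on the series, on what has been measured and on what is new or still open speak of the compounds shown alone.

Notes on the series in an ADME assay on Vero cells (Chlorocebus sabaeus) for inhibition, read by fluorescence and resazurin assay, with a stated time of 24 h; on this read-out higher numbers stand for lower toxicity in this test and lower numbers for higher toxicity in this test. Compound 1 `C=CCn1c2ccc([N+](=O)[O-])cc2c(=O)n1Cc1ccccc1` has no numerical result, entered as "not determined" (no result reported). Compound 2 `Cc1ccc(S(=O)(=O)n2c3ccc([N+](=O)[O-])cc3c(=O)n2Cc2ccccc2)cc1` is likewise entered as "not determined" (no result reported). Compound 3 `COC(=O)CCOc1c2cc([N+](=O)[O-])ccc2nn1Cc1ccccc1` stands only at a limit, > 300000 nM, which is not a number, so the series offers no measured value to work from. Compound 4 `O=[N+]([O-])c1ccc2nn(Cc3ccccc3)c(OCCO)c2c1` differs from compound 3 in having hydroxy in place of methoxycarbonyl on a saturated chain carbon, two bonds along the chain from an oxygen on an aromatic ring. For the measured compounds named here, no measured step in this assay covers this change. The estimated step of an at least 1.2-fold lower number from compound 3 to compound 4 (0.07 log units; that floor lies within the scatter) is expected to stay within the usual scatter, if anything toward lower numbers. For compound 4 the expected value is 250000 nM, with an estimated range of 90000 nM to 400000 nM.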

Compound 4, half-maximal cytotoxic concentration: > 300000 nM
Compound 4: only a limit was reported (the forecaster's own chance of this, stated with the estimate: 55%); middle value at least 1.2-fold (0.07 log units) away from the limit.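

No step can be read from compound 3 to compound 4, since both entries are limits and not numbers: the limit of > 300000 nM in this assay, at which 2 of the 4 values shown sit. The compounds shown leave open whether 2-(methoxycarbonyl)ethoxy to 2-hydroxyethoxy shifts the half-maximal cytotoxic concentration at all.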